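Dichlorophenyl replacing trimethoxyphenyl on the anilino nitrogen

A few compounds are considered here, and "the series" means these few. Any claim that something is new, unique, unknown or untested is made for them only; others in the source may bear on it.

Compound 1 `C=CC(=O)Nc1cccc(NC(=O)CSc2nc(Nc3ccc(CC)cc3)c3ccccc3n2)c1` carries a 4-ethylphenyl on the anilino nitrogen of the shared core; in a functional assay on NCI-H1975 cells (Homo sapiens) for inhibition, read by MTT assay, with a stated time of 72 h (on this read-out higher numbers stand for weaker inhibition and lower numbers for stronger inhibition), compound 1 gives 8270 nM. Compound 2 `C=CC(=O)Nc1cccc(NC(=O)CSc2nc(Nc3cc(OC)c(OC)c(OC)c3)c3ccccc3n2)c1` swaps that group for 3,4,5-trimethoxyphenyl. In this assay compound 2 gives only a limit, > 50000 nM, so its true value is not known. The step of an at least 6.0-fold higher number from compound 1 to compound 2 (0.78 log units; beyond the scatter) is at least modest, and compound 2 sits at the limit of > 50000 nM in this assay, at which 1 of the 2 values shown sits. Compound 3 `C=CC(=O)Nc1cccc(NC(=O)CSc2nc(Nc3ccc(Cl)c(Cl)c3)c3ccccc3n2)c1` changes the same position again: 3,4-dichlorophenyl in place of 3,4,5-trimethoxyphenyl on a nitrogen on an aromatic ring. Going by the values given here, only the step from compound 1 to compound 2 bears on this, and it shows that the trimethoxy group is the weak end of the pair. A return toward a smaller, acceptor-free aryl is therefore expected to give a lower number, of size an at least 5.5-fold lower number from compound 2 to compound 3 (0.74 log units; beyond the scatter), though with a real chance that compound 3 also stays at the limit. Compound 3 is estimated at 9000 nM, within 2500 nM to 50000 nM.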

Compound 3, half-maximal inhibitory concentration: 19100 nM
For compound 3 the middle estimate is 2.1-fold (0.33 log units) below the measured one; the measured number falls inside the stated range.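

Both new steps fall at the same position, on a nitrogen on an aromatic ring. 3,4-dichlorophenyl in place of 3,4,5-trimethoxyphenyl gives an at least 2.6-fold lower number from compound 2 to compound 3 (0.41 log units; beyond the scatter), so the weak result in this assay is not shared by every substituted phenyl here. 3,4-dichlorophenyl in place of 4-ethylphenyl still gives a 2.3-fold higher number from compound 1 to compound 3 (0.36 log units; beyond the scatter), which places 3,4-dichlorophenyl between the other two groups, although compound 2 is a limit and fixes only one side of that order: the limit of > 50000 nM in this assay, at which 1 of the 3 values shown sits.

With only three aryl groups, which differ in more than one way at once, the compounds shown do not separate the effect of the number of substituents from that of their identity. Where an unsubstituted phenyl, a monochlorophenyl or a single methoxyphenyl would fall in this order remains open.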